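Fluoro for methoxy on a thioether-linked quinoxaline series

The source may report more compounds than this note shows. Statements on the series, on what has been measured and on what is new or still open speak of the compounds shown alone.

Of the compounds shown here, three sharing one core have been tested in a functional assay on LOX IMVI cells (Homo sapiens) for inhibition, read by sulforhodamine B assay, with a stated time of 48 h; a higher number here means that more compound is tolerated, a lower number that less compound is tolerated. Compound 1 `CCOC(=O)[C@H](CCC(=O)O)NC(=O)c1ccc(Sc2nc3cc(N)cc(N)c3nc2-c2ccccc2)cc1` reached only a limit, < 100000 nM. Compound 2 `COc1cc(CNc2nc3cc(N)cc(N)c3nc2-c2ccccc2)cc(OC)c1OC` gave 26300 nM. Compound 3 `COc1ccc(Sc2nc3cc(N)cc(N)c3nc2-c2ccccc2)cc1` likewise reached only a limit, < 100000 nM. Two of the three values thus sit at the limit of < 100000 nM in this assay, at which 2 of the 3 values shown sit, so compound 3 cannot be placed above or below its neighbours on a number. The untested compound 4 `Nc1cc(N)c2nc(-c3ccccc3)c(Sc3ccc(F)cc3)nc2c1` differs from compound 3 by fluoro in place of methoxy on an aromatic carbon. For the measured compounds named here, with no measured step between two numbered compounds, and compound 3 itself known only as a limit, the author expects a change no larger than the usual scatter, in no particular direction. Compound 4 is therefore estimated at 30000 nM, within 8000 nM to 100000 nM, implying a step that the limit leaves unreadable from compound 3 to compound 4.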

Compound 4, concentration lethal to 50% of the cells: 74100 nM
The estimate for compound 4 lay 2.5-fold (0.39 log units) below the measured number; the range from low to high includes it.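

No step can be read between compound 3 and compound 4, because compound 3 carries only a limit: the limit of < 100000 nM in this assay, at which 2 of the 4 values shown sit. The compounds shown leave open whether fluoro in place of methoxy shifts the value in this assay at all, and in which direction.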